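Methoxy to hydroxy: what to expect for compound 3

The source may report more compounds than this note shows. Statements on the series, on what has been measured and on what is new or still open speak of the compounds shown alone.

In a functional assay on HepG2 cells (Homo sapiens) for antiproliferative activity, read by MTT assay, with a stated time of 48 h (a lower number here means a stronger inhibitor, a higher number a weaker inhibitor), compound 1 (`COc1ccc(-c2c(Nc3ccc(F)cc3)c3ccc(OC)cc3oc2=O)cc1`) shows > 100000 nM as a limit of the assay and not a number. Going by the values given here, compound 2 (`COc1ccc(-c2c(Nc3ccc(C)cc3)c3ccc(OC)cc3oc2=O)cc1`) gives 74400 nM as the only actual number so far. Among the compounds with values here, the single measured step is an at least 1.3-fold lower number from compound 1 to compound 2 (0.12 log units; that floor lies within the scatter) and it concerns another change, methyl in place of fluoro on an aromatic carbon. Compound 3 (`COc1ccc(-c2c(Nc3ccc(C)cc3)c3ccc(O)cc3oc2=O)cc1`) differs from compound 2 by hydrogen in place of methyl on an oxygen on an aromatic ring, that is, methoxy to hydroxy (hydrogen in place of methyl on an oxygen on an aromatic ring). Within the data shown here, no measured step covers this change, so the data point in neither direction. Among the measured compounds shown here, the only anchor is compound 2 at 74400 nM and the expectation stays close to it. The expected move is a 1.2-fold lower number from compound 2 to compound 3 (0.09 log units; within the scatter) in this assay with no step beyond the scatter. Compound 3 is estimated at 60000 nM with an expected range of 20000 nM to 150000 nM for this compound.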

Compound 3, half-maximal inhibitory concentration: 88300 nM
Compound 3: middle estimate off by 1.5-fold (0.17 log units), on the low side, within the range that was stated.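

Hydrogen in place of methyl on this oxygen gives a 1.2-fold higher number from compound 2 to compound 3 (0.07 log units; within the scatter) in this assay, the first measured step at this place, and compound 2 and compound 3 cannot be told apart on it. Methoxy and hydroxy at this place therefore both leave a high number, with compound 3 at 88300 nM, so a free hydroxy here brings no gain in potency that this measurement can detect. Readings this high also leave little room to resolve small differences, since the series already reaches the limit of the assay: the limit of > 100000 nM in this assay, at which 1 of the 3 values shown sits.

On these data alone, an amine, a carboxylic acid or a longer chain on the same aromatic carbon remains open, as a step this small cannot predict how any of them would read. So does the effect of changing the methoxy group that remains in compound 3.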